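The source may hold more compounds than are shown below. What is called first, only, known or untested is meant among the compounds shown, and "the series" means these compounds.

Series notes. For the measured compounds named here, compound 1 `CSc1ccc(-c2nc3c(Sc4ccc(F)cc4)ncnc3n2C)cc1` and compound 2 `Cn1c(-c2ccc(S(C)(=O)=O)cc2)nc2c(Sc3ccccc3)ncnc21` share a core and differ at two places, so no single step connects them. In an assay on isolated protein for inhibition of RAC-alpha serine/threonine-protein kinase (Homo sapiens), tested at 30 uM (on this read-out lower numbers stand for less inhibition and higher numbers for more inhibition at the one concentration tested (going by the name of the read-out)), compound 1 gives 0% and compound 2 gives 14%; compound 2 thus holds the higher of the two numbers, and the gap to compound 1 lies beyond the scatter. Compound 3 `Cn1c(-c2ccc(S(C)(=O)=O)cc2)nc2c(Sc3ccc(F)cc3)ncnc21` has not been measured. It differs from compound 2 by fluoro in place of hydrogen on an aromatic carbon. Nothing measured here isolates that change, so the step from compound 2 to compound 3 is expected to be small, a number 2 percentage points lower from compound 2 to compound 3 (within the scatter), in either direction and within the scatter. Compound 3 is estimated at 12%, range 0% to 30%.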

Compound 3, a percentage reported as inhibition, at one concentration (the size of the read-out at that concentration, not a potency): 4%
Estimate against measurement, compound 3: 8 percentage points above; the range from low to high includes it.
By their numbers in this assay, from the lowest: compounds 1, 3 and 2 (each within the scatter of the next, the first and the last beyond it).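

In this assay fluoro in place of hydrogen, now isolated with the methylsulfonyl group held fixed, gives a number 10 percentage points lower from compound 2 to compound 3 (within the scatter) and so shows no separable effect at this position. Methylsulfonyl in place of methylsulfanyl, with the (4-fluorophenyl)sulfanyl group held fixed, gives a number 4 percentage points higher from compound 1 to compound 3 (within the scatter) and so each single change stays within the scatter, although compound 1 and compound 2 lie beyond it. No supporting data bear on these steps.

From the compounds shown here alone, whether an amine or a carboxylic acid on this aromatic carbon would move the inhibition beyond the scatter remains open.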